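Amide chain length against adenosine receptor binding

The source may report more compounds than this note shows. Statements on the series, on what has been measured and on what is new or still open speak of the compounds shown alone.

Measured in an assay on brain for binding affinity to adenosine receptor A1 (Rattus norvegicus), in the presence of a further agent that is not named here; a lower number here means a stronger inhibitor, a higher number a weaker inhibitor:
- compound 1 `O=C(CCc1ccccc1)N[C@@H]1[C@@H](O)[C@H](n2cnc3c(NC4CCCC4)ncnc32)O[C@@H]1CO` gives 350 nM
- compound 2 `O=C(CCCc1ccccc1)N[C@@H]1[C@@H](O)[C@H](n2cnc3c(NC4CCCC4)ncnc32)O[C@@H]1CO` gives 100 nM

Among the measured compounds shown here, compound 2 holds the lower of the two numbers; its only neighbour is compound 1, and the step between them, a 3.5-fold lower number from compound 1 to compound 2 (0.54 log units; beyond the scatter), lies beyond the scatter. Compound 3 `O=C(CCCCc1ccccc1)N[C@@H]1[C@@H](O)[C@H](n2cnc3c(NC4CCCC4)ncnc32)O[C@@H]1CO` carries the same kind of change one position further out: benzyl in place of phenyl on a saturated chain carbon, three bonds along the chain from a carbonyl carbon. For the measured compounds named here, the only measured step that bears on it is the one already named, a modest gain on lengthening the chain. Two compounds cannot show whether a further lengthening keeps gaining, so the expected step of a 1.4-fold lower number from compound 2 to compound 3 (0.15 log units; within the scatter) is set in the same direction but smaller, and it may well fall within the scatter. Compound 3 is therefore expected near 70 nM, with a range from 25 nM to 250 nM.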

Compound 3, inhibition constant: 200 nM
The estimate for compound 3 lay 2.9-fold (0.46 log units) below the measured number; low and high end bracket the measured number.
By their numbers in this assay, from the lowest: compounds 2, 3 and 1 (each within the scatter of the next, the first and the last beyond it).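

Benzyl in place of phenyl, three bonds along the chain from a carbonyl carbon, gives a 2.0-fold higher number from compound 2 to compound 3 (0.30 log units; within the scatter) in this assay and so does not repeat the gain seen from phenethyl to 3-phenylpropyl. Among the compounds shown here, the whole span gives a 1.8-fold lower number from compound 1 to compound 3 (0.24 log units; within the scatter) in this assay as well, so no steady trend with chain length holds: only the pair with phenethyl and 3-phenylpropyl chains is separated beyond the scatter, and the 4-phenylbutyl compound is separated from neither. Nothing at hand gives a reason for this behaviour of the chain.

Going by these compounds, whether a longer chain such as 5-phenylpentyl keeps the number at this level remains open. Also open, on these data alone, is what an amine or a carboxylic acid in place of the terminal phenyl would do at this position.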